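A few compounds are considered here, and "the series" means these few. Any claim that something is new, unique, unknown or untested is made for them only; others in the source may bear on it.

Measured compounds:

- compound 1, `CC(C)CCSc1nc(C(F)(F)F)ccc1CNC(=O)C(C)c1ccc(NS(C)(=O)=O)c(F)c1`: 0.7 nM
- compound 2, `CC(C(=O)NCc1ccc(C(F)(F)F)nc1SCCOc1ccccc1)c1ccc(NS(C)(=O)=O)c(F)c1`: 2.3 nM
- compound 3, `CC(C(=O)NCc1ccc(C(F)(F)F)nc1SCCCN1CCCCC1)c1ccc(NS(C)(=O)=O)c(F)c1`: 3 nM

In an assay on CHO-K1 cells for antagonist activity at transient receptor potential cation channel subfamily V member 1 (Homo sapiens), read by FLIPR (on this read-out higher numbers stand for weaker inhibition and lower numbers for stronger inhibition), compound 3 gives 3 nM, the highest of the three numbers. Its nearest neighbour is compound 2, and the gap between them is within the scatter, so the two cannot be told apart; compound 1 lies furthest away, and that gap is beyond the scatter.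

Compound 4, `CC1CCC(Sc2nc(C(F)(F)F)ccc2CNC(=O)C(C)c2ccc(NS(C)(=O)=O)c(F)c2)CC1`, is not yet measured. The change from compound 3 is 4-methylcyclohexyl in place of 3-(piperidin-1-yl)propyl on a sulfur. Among the measured compounds shown here, two measured steps bear on it: a 4.3-fold higher number from compound 1 to compound 3 (0.63 log units; beyond the scatter) and a 3.3-fold higher number from compound 1 to compound 2 (0.52 log units; beyond the scatter), both modest and beyond the scatter, show that swapping the isopropyl of compound 1 for a group carrying a hetero atom raised the number. The third step, a 1.3-fold higher number from compound 2 to compound 3 (0.12 log units; within the scatter), lies within the scatter. Compound 4 goes the other way, back to a ring of carbon only with no hydrogen-bond acceptor, much like compound 1. A modest step toward a lower number is therefore expected, a 2.5-fold lower number from compound 3 to compound 4 (0.40 log units; beyond the scatter). The estimate for compound 4 in this assay is 1.2 nM, with a range from 0.4 nM to 3.5 nM.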

Compound 4, inhibition constant: 0.5 nM
Compound 4: the middle estimate sits 2.4-fold (0.38 log units) above what was measured; measured number inside the range.
By their numbers in this assay, from the lowest: compounds 4 and 1 (each within the scatter of the next); then compounds 2 and 3 (each within the scatter of the next).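

In this assay, a carbon-only ring on the sulfur does as well as the open isopentyl chain: the step (a 1.4-fold lower number from compound 1 to compound 4 (0.15 log units; within the scatter)) leaves compounds 1 and 4 indistinguishable. Among the compounds shown here, the same ring stands clearly apart from both groups carrying a hetero atom (a 6.0-fold lower number from compound 3 to compound 4 (0.78 log units; beyond the scatter); a 4.6-fold lower number from compound 2 to compound 4 (0.66 log units; beyond the scatter)), so across these four compounds the two carbon-only groups share the low numbers, with no compound going against that split, and the six-membered ring of compound 3 shows that a ring alone does not secure a low number. Nothing measured here explains these differences.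

Still open, on these data alone, is whether the hetero atom itself or its place along the chain sets the number, which a 2-methoxyethyl or a 2-(piperidin-1-yl)ethyl group could test. An unsubstituted cyclohexyl group would show whether the ring's methyl matters.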